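The source may hold more compounds than are shown below. What is called first, only, known or untested is meant among the compounds shown, and "the series" means these compounds.

Compound 2 `CCn1ncc2c(N3CC4CCC(C3)O4)nc(-c3ccc(NC(=O)NC)cc3)nc21` has been run in an in vitro ADME assay on microsomes (Mus musculus) for metabolic stability (on this read-out higher numbers stand for a longer-lived compound and lower numbers for a shorter-lived compound), and gives > 0.5 h, which is a limit of the assay rather than a number. Compound 1 `O=C(Nc1ccccc1)Nc1ccc(-c2nc(N3CC4CCC(C3)O4)c3cnn(C4CCC5(CC4)OCCO5)c3n2)cc1` gives > 0.5 h in this assay, again a limit. Both measured values therefore stand at the limit of > 0.5 h in this assay, at which 2 of the 2 values shown sit, so no ordering between them can be read. Compound 3 `CNC(=O)Nc1ccc(-c2nc(N3CC4CCC(C3)O4)c3cnn(C4CCC5(CC4)OCCCO5)c3n2)cc1` carries a group of 11 heavy atoms (9 carbon, 2 oxygen; one six-membered non-aromatic ring of carbon only, one six-membered non-aromatic ring with 2 hetero atoms) in place of a group of 2 heavy atoms (2 carbon; no ring), on an aromatic nitrogen. Among the compounds with values here, no step between measured compounds is available to size this change. Since both measured values sit at the limit, no step beyond the usual scatter is expected in either direction. Compound 3 is estimated at 0.8 h, between 0.4 h and 1.6 h, with an expected step that the limit leaves unreadable from compound 2 to compound 3.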

Compound 3, half-life: > 0.5 h
Compound 3 gave a limit, no number; the forecaster's own chance of this, stated with the estimate: 70%; the middle value lies beyond the limit too.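

In this assay, within the data shown here, compound 3 gives > 0.5 h, a limit, so no step from compound 2 to compound 3 can be read. The compounds shown leave open the actual half-life of each compound and whether the group in place of ethyl changes it: the limit of > 0.5 h in this assay, at which 3 of the 3 values shown sit.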